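The source may report more compounds than this note shows. Statements on the series, on what has been measured and on what is new or still open speak of the compounds shown alone.

Compound 1 `CCCCCC(=O)NCC(=O)N(C)c1ccc(Cl)cc1C(=O)c1ccccc1Cl`: 90 mg/kg
Compound 2 `NCC(=O)NCC(=O)Nc1ccc([N+](=O)[O-])cc1C(=O)c1ccccc1Cl`: 63.9 mg/kg

In a functional assay on the whole organism with Mus musculus as the target, in the rotarod test (a lower number here means that less compound is needed, a higher number that more compound is needed for the effect), compound 1 gives 90 mg/kg, and compound 2 gives 63.9 mg/kg; these two numbers lie within the usual scatter of each other, so neither compound stands apart. Compound 3 `CN(C)CC(=O)NCC(=O)N(C)c1ccc(Cl)cc1C(=O)c1ccccc1Cl` differs from compound 1 in one place: dimethylamino in place of butyl on a saturated chain carbon bound to a carbonyl carbon. Among the measured compounds shown here, no measured pair carries this change, so there is no step to lean on. The expected step is a 1.2-fold lower number from compound 1 to compound 3 (0.08 log units; within the scatter), which means nothing beyond the scatter, in no firm direction. Compound 3 is therefore expected near 75 mg/kg, within a range from 35 mg/kg to 160 mg/kg.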

Compound 3, dose for half-maximal effect: 26 mg/kg
Beside the measured number, compound 3's estimate is 2.9-fold (0.46 log units) above it; the measured number lies below the stated range.
By their numbers in this assay, from the lowest: compound 3; then compounds 2 and 1 (each within the scatter of the next).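

Replacing butyl with dimethylamino on a saturated chain carbon bound to a carbonyl carbon gives, in this assay, (a 3.5-fold lower number from compound 1 to compound 3 (0.54 log units; beyond the scatter)), a step beyond the scatter. Among the compounds shown here, compounds 1 and 2 differ in more than one place, so only this pair shows that a change at this position alone can move the number. No available evidence accounts for the step.

Going by these compounds, it remains open whether diethylamino or a carboxylic acid at this place would move the number in the same direction. A shorter carbon chain with no nitrogen is equally untested by the compounds shown.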